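Replacing the (2-Phenylethenyl)carbonyl Group of Compound 1

This account rests on a few compounds, and the source may have more. Where it says the series, first, only, none or still open, it means among the compounds named here.

In a functional assay on HeLa cells (Homo sapiens) for cytotoxicity, read by MTT assay, with a stated time of 48 h (on this read-out higher numbers stand for weaker inhibition and lower numbers for stronger inhibition), compound 1 `CCN(CC)c1ccc2cc(C(=O)c3ccc(N4CCN(C(=O)CN5CCN(C(=O)/C=C/c6ccccc6)CC5)CC4)cc3)oc2c1` gives 5260 nM, the higher of the two numbers recorded, though compound 3 `CCN(CC)c1ccc2cc(C(=O)c3ccc(N4CCN(C(=O)CN5CCN(Cc6ccc(/C=C/C(=O)OC)cc6)CC5)CC4)cc3)oc2c1` at 3040 nM lies within the scatter of it. Compound 2 `C#CCN1CCN(CC(=O)N2CCN(c3ccc(C(=O)c4cc5ccc(N(CC)CC)cc5o4)cc3)CC2)CC1` reaches only an assay limit, > 40000 nM (the limit of > 40000 nM in this assay, at which 1 of the 3 values shown sits). Compound 4 `CCN(CC)c1ccc2cc(C(=O)c3ccc(N4CCN(C(=O)CN5CCN(CC(C)=O)CC5)CC4)cc3)oc2c1` differs from compound 1 in one place: 2-oxopropyl in place of (2-phenylethenyl)carbonyl on an amine nitrogen in a ring. For the measured compounds named here, two measured steps bear on this change. Exchanging the same group for propargyl gave an at least 7.6-fold higher number from compound 1 to compound 2 (0.88 log units; beyond the scatter), while placing an aryl group on that nitrogen gave an at least 13-fold lower number from compound 2 to compound 3 (1.11 log units; beyond the scatter). The 2-oxopropyl group, like propargyl, brings no ring to that nitrogen; a higher number is therefore expected, a 5.7-fold higher number from compound 1 to compound 4 (0.76 log units; beyond the scatter). Compound 4 is estimated at 30000 nM, with a range from 10000 nM to 80000 nM, and may well return only a limit.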

Compound 4, half-maximal inhibitory concentration: 2760 nM
The estimate for compound 4 lay 11-fold (1.04 log units) above the measured number; measured number below the stated range.
By their numbers in this assay, from the lowest: compounds 4, 3 and 1 (each within the scatter of the next). At a limit, above all of these: compound 2.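

In this assay a ring on this nitrogen proves dispensable: 2-oxopropyl in place of (2-phenylethenyl)carbonyl gives a 1.9-fold lower number from compound 1 to compound 4 (0.28 log units; within the scatter) and the exchange for the aryl-bearing end gives a 1.1-fold lower number from compound 3 to compound 4 (0.04 log units; within the scatter) with no ring in the entering group. The two ringless ends do part, with acetyl in place of ethynyl on the saturated chain carbon giving an at least 14-fold lower number from compound 2 to compound 4 (1.16 log units; beyond the scatter) in this assay, so the presence of a ring alone does not set the number here. That step starts from a limit: the limit of > 40000 nM in this assay, at which 1 of the 4 values shown sits. The compounds shown leave open whether the carbonyl of 2-oxopropyl or the ethynyl end accounts for this step, and whether an amine, a carboxylic acid or a longer chain on that carbon would keep these numbers.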